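Ethyl to Cyclobutylcarbonyl on the Ring Amine of Compound 3

A few compounds are considered here, and "the series" means these few. Any claim that something is new, unique, unknown or untested is made for them only; others in the source may bear on it.

Compound 1, `Cc1cccc(C#Cc2nc3c(s2)C(=O)NCC3)c1`, in an assay on HEK293 cells for positive allosteric modulation of metabotropic glutamate receptor 5 (Homo sapiens), read by FLIPR, with a stated time of 1 h (a lower number here means that less compound is needed, a higher number that more compound is needed for the effect), is reported only as the limit > 10000 nM.
Compound 2, `O=C1c2sc(C#Cc3ccccc3)nc2CN1C1CC1`, in this assay is reported only as the limit > 10000 nM.
Compound 3, `CCN1CCc2nc(C#Cc3ccccc3)sc2C1`, in this assay is reported only as the limit > 10000 nM.

Going by the values given here, compound 3 therefore stands where every compound measured so far stands: not at a number but at a limit, described by the limit of > 10000 nM in this assay, at which 3 of the 3 values shown sit. Among the compounds with values here, no pair of these three compounds differs in a single place, so no measured step exists to set the size of any change, and nothing among them ranks one against another.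

Within the data shown here, compound 4, `O=C(C1CCC1)N1CCc2nc(C#Cc3ccccc3)sc2C1`, is the only compound not yet measured. It differs from compound 3 by cyclobutylcarbonyl in place of ethyl on an amine nitrogen in a ring. Among the measured compounds shown here, since no measured step is known, the direction of this change can only be estimated. For compound 4 the step of an at least 12-fold lower number from compound 3 to compound 4 (1.09 log units; beyond the scatter) is expected to go toward a lower number in this assay, beyond the usual scatter, because compound 3 is known only by the limit > 10000 nM and any reported number would already lie below it. Compound 4 is estimated at 800 nM, with a range from 100 nM to 10000 nM.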

Compound 4, half-maximal effective concentration: > 10000 nM
Compound 4: only a limit was reported; the forecaster's own chance of this, stated with the estimate: 40%; middle value at least 12-fold (1.09 log units) from the limit.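

Compound 3 and compound 4 are both reported only as limits, so no step between them can be read, and all the compounds shown stand at one limit: the limit of > 10000 nM in this assay, at which 4 of the 4 values shown sit.

The compounds shown leave open how cyclobutylcarbonyl and ethyl on the ring amine truly compare in this assay.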